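The source may report more compounds than this note shows. Statements on the series, on what has been measured and on what is new or still open speak of the compounds shown alone.

Measured so far:
- compound 1 `CC(=O)N(C)C(C)C#CCn1ccnc1`: > 100 mg/kg (limit)
- compound 2 `CC(=O)N(C)CC#CCn1ccnc1`: > 100 mg/kg (limit)
- compound 3 `CC(=O)N(C)CC#CCn1cncc1C`: > 100 mg/kg (limit)

The read-out is a functional assay on the whole organism for antagonist activity, with Mus musculus as the target; on this read-out higher numbers stand for an effect only at larger amounts of compound and lower numbers for an effect already at smaller amounts. Compound 2 stands at > 100 mg/kg, which is a limit and not a number. Among the measured compounds shown here, the whole series so far sits at one point: the limit of > 100 mg/kg in this assay, at which 3 of the 3 values shown sit.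

Compound 4 `CN(C)C(=O)N(C)CC#CCn1ccnc1` is the next entry. The change is dimethylamino in place of methyl on a carbonyl carbon, or acetyl to dimethylcarbamoyl.

Two measured steps are available: a step that the two limits leave unreadable from compound 1 to compound 2, and a step that the two limits leave unreadable from compound 2 to compound 3. Neither is made at the carbonyl carbon, and neither has a readable size, so they give no guide to size or direction at this position. In this assay the working expectation is therefore no clear shift, and a number no higher from compound 2 to compound 4 (the limit leaves the size open) is expected with low confidence. A further limit is the likeliest report, though a measurable value cannot be excluded. For compound 4 the estimated value is 100 mg/kg, with an expected range of 40 mg/kg to 300 mg/kg.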

Compound 4, dose for half-maximal effect: > 100 mg/kg
Compound 4: a limit, no number; the forecaster's own chance of this, stated with the estimate: 75%; the middle value sits exactly at the limit.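

In this assay compound 4 gives > 100 mg/kg, a limit and not a number, and no new step can be read against compound 2, which also stands at a limit. The compounds shown leave open whether any change to the shared core gives a measurable dose: the limit of > 100 mg/kg in this assay, at which 4 of the 4 values shown sit.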